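The compounds below may be only part of what the source reports. "The series", "measured", "known", "first", "only" and "open" are said of these compounds alone.

Compound 1, `CC(C)c1cccc(C(C)C)c1N1CNC(C(c2ccccc2)c2ccccc2)C1=O`, gives 3900 nM in an assay on microsomes from intestine for inhibition of acyl-CoA:cholesterol acyltransferase (Oryctolagus cuniculus); a lower number here means a stronger inhibitor, a higher number a weaker inhibitor.
Compound 2, `CCCCCCCC/C=C\CCCCCCCC1=NN(c2c(Cl)cccc2Cl)C(=O)C1`, gives 22900 nM.

Of these two numbers, compound 2 has the higher one; compound 1 stands lower, and the gap between them is beyond the usual scatter. The two compounds share no single point of difference, so their values can only be set side by side, and nothing more is drawn from the pair.

Compound 3, `CCCCCCCC/C=C\CCCCCCCC1=NN(c2ccc(C)cc2C)C(=O)C1`, has not yet been measured. It differs from compound 2 in one place: 2,4-dimethylphenyl in place of 2,6-dichlorophenyl on an amide-type nitrogen in a ring. Among the compounds with values here, no measured pair in this set shows a change of this kind, so the size of the step is open. The account here expects a small weakening from compound 2 to compound 3, estimated as a 1.5-fold higher number from compound 2 to compound 3 (0.18 log units; within the scatter), though a step within the scatter would not be surprising. For compound 3 the estimate is 35000 nM, with a range from 12000 nM to 100000 nM.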

Compound 3, half-maximal inhibitory concentration: 5000 nM
Beside the measured number, compound 3's estimate is 7.0-fold (0.85 log units) above it, and the stated range ends above it.
By their numbers in this assay, from the lowest: compounds 1 and 3 (each within the scatter of the next); then compound 2.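

On the amide-type nitrogen in the ring, with the rest of the molecule unchanged, 2,4-dimethylphenyl in place of 2,6-dichlorophenyl gives a 4.6-fold lower number from compound 2 to compound 3 (0.66 log units; beyond the scatter) in this assay. Within the data shown here, this is the only readable step in the set, and it shows that the number in this assay responds to the substituents on this aryl group, with the dimethyl pattern giving the stronger inhibitor of the pair. No measurement shown here explains why the number falls.

On these data alone, the step changes both the atoms and their pattern on the ring, so it remains open whether the chlorines leaving, the methyl groups entering or the altered pattern accounts for it. As far as these compounds go, a 2,6-dimethylphenyl or 2,4-dichlorophenyl group on the same nitrogen would separate these, and whether the step holds with a shorter chain also remains open.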